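This account rests on a few compounds, and the source may have more. Where it says the series, first, only, none or still open, it means among the compounds named here.

Of the compounds shown here, three sharing one core have been measured in a functional assay on HeLa cells (Homo sapiens) for antiproliferative activity, read by CCK-8 assay, with a stated time of 72 h; on this read-out lower numbers stand for stronger inhibition and higher numbers for weaker inhibition. Compound 1 `O=C(Nc1cccc(-c2oc3cc(-c4ccc(F)cc4)ccc3c(=O)c2O)c1)c1ccc(F)cc1F` gives 10700 nM in this assay. Compound 2 `O=C(Nc1cccc(-c2oc3cc(-c4ccc(F)cc4)ccc3c(=O)c2O)c1)c1ccc(Br)cc1` gives 9740 nM in this assay. Compound 3 `N#Cc1ccc(C(=O)Nc2cccc(-c3oc4cc(-c5ccc(F)cc5)ccc4c(=O)c3O)c2)cc1` gives 23300 nM in this assay, the highest of the three numbers. The change a 1.1-fold lower number from compound 1 to compound 2 (0.04 log units; within the scatter) lies within the scatter, whereas a 2.2-fold higher number from compound 1 to compound 3 (0.34 log units; beyond the scatter) and a 2.4-fold higher number from compound 2 to compound 3 (0.38 log units; beyond the scatter) both go beyond it, so compound 3 stands apart from the other two at the weaker end.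

Compound 4 `CCCc1ccc(C(=O)Nc2cccc(-c3oc4cc(-c5ccc(F)cc5)ccc4c(=O)c3O)c2)cc1` has not yet been measured. It differs from compound 3 in one place: propyl in place of cyano on an aromatic carbon. The step that bears most directly on this change is a 2.4-fold higher number from compound 2 to compound 3 (0.38 log units; beyond the scatter), in which a cyano entered on the same aromatic carbon and the number rose. The step to compound 4 removes that cyano again, now in favour of a propyl, and a 2.2-fold higher number from compound 1 to compound 3 (0.34 log units; beyond the scatter) points the same way, though neither measured step involves a propyl, so the comparison is indirect. Compound 4 is therefore expected to show a modest fall in this assay, a 2.1-fold lower number from compound 3 to compound 4 (0.33 log units; beyond the scatter). Compound 4 is estimated at 11000 nM, with a range from 5000 nM to 25000 nM.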

Compound 4, half-maximal inhibitory concentration: 8790 nM
Beside the measured number, compound 4's estimate is 1.3-fold (0.10 log units) above it, and the stated range covers the measured number.
By their numbers in this assay, from the lowest: compounds 4, 2 and 1 (each within the scatter of the next); then compound 3.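

In this assay, putting a propyl on the aromatic carbon para to a large group in place of the cyano gives a 2.7-fold lower number from compound 3 to compound 4 (0.42 log units; beyond the scatter), which shows that the higher number of compound 3 is not shared by a plain alkyl chain at this position. The propyl also joins the groups already measured here, with a 1.1-fold lower number from compound 2 to compound 4 (0.04 log units; within the scatter) and a 1.2-fold lower number from compound 1 to compound 4 (0.09 log units; within the scatter), so 4-propylphenyl, 4-bromophenyl and 2,4-difluorophenyl cannot be told apart in this assay, and among the four compounds only the 4-cyanophenyl of compound 3 goes against this flat picture. No measurement is available to explain why the cyano alone stands apart from the other groups.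

What the compounds leave open is whether this flat picture holds for a longer chain such as hexyl, or for a group of another kind such as a primary amine or a carboxylic acid on the same carbon. They also leave open whether any group at this position can bring the number clearly below the shared level of compound 1, compound 2 and compound 4.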